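Fluorophenyl for methylphenyl on the shared core

The compounds below may be only part of what the source reports. "The series", "measured", "known", "first", "only" and "open" are said of these compounds alone.

In a functional assay on CHO cells for agonist activity at Free fatty acid receptor 1 (Homo sapiens), read by FLIPR and calcium flux, tested at 100 nM (on this read-out lower numbers stand for a weaker effect and higher numbers for a stronger effect at the one concentration tested), compound 1 `Cc1nc(-c2ccccc2)sc1COc1ccc2c(c1)OCC2CC(=O)O` gives 54.8%, compound 2 `Cc1nc(-c2ccsc2)sc1COc1ccc2c(c1)OCC2CC(=O)O` gives 56.5%, and compound 3 `Cc1ccc(-c2nc(C)c(COc3ccc4c(c3)OCC4CC(=O)O)s2)cc1` gives 54.9%, which is the second highest of the three numbers, nearest to compound 1 and furthest from compound 2, with both gaps inside the scatter. Exchanging the aryl group on the five-membered aromatic ring with 1 nitrogen and 1 sulfur has not moved the read-out: a number 1.7 percentage points higher from compound 1 to compound 2 (within the scatter), a number 0.1 percentage points higher from compound 1 to compound 3 (within the scatter), and a number 1.6 percentage points lower from compound 2 to compound 3 (within the scatter). Compound 4 `Cc1nc(-c2cccc(F)c2)sc1COc1ccc2c(c1)OCC2CC(=O)O` carries 3-fluorophenyl in place of 4-methylphenyl on an aromatic carbon. Because a number 0.1 percentage points higher from compound 1 to compound 3 (within the scatter) and a number 1.6 percentage points lower from compound 2 to compound 3 (within the scatter) both stay within the scatter, the expected step of a number 0.1 percentage points higher from compound 3 to compound 4 (within the scatter) is likewise none beyond the scatter. Compound 4 is therefore estimated at 55%, ranging from 44% to 66%.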

Compound 4, a percentage reported as activity, at one concentration (the size of the read-out at that concentration, not a potency): 56.9%
Compound 4: middle estimate off by 1.9 percentage points, on the low side; measured number inside the range.
By their numbers in this assay, from the lowest: compounds 1, 3, 2 and 4 (each within the scatter of the next).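

In this assay, within the data shown here, 3-fluorophenyl is the first group at this position to carry fluorine, and it reads the same as the three groups before it: the phenyl of compound 1 (a number 2.1 percentage points higher from compound 1 to compound 4 (within the scatter)), the thiophen-3-yl of compound 2 (a number 0.4 percentage points higher from compound 2 to compound 4 (within the scatter)) and the 4-methylphenyl of compound 3 (a number 2 percentage points higher from compound 3 to compound 4 (within the scatter)). Fluoro in place of hydrogen on the phenyl group therefore leaves the read-out as flat as the methyl did. Going by these compounds, whether an amine or a carboxylic acid on this aryl group, or a longer chain in its place, would move the number stays open. No evidence at hand bears on this flat picture.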